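The source may hold more compounds than are shown below. What is called first, only, known or untested is meant among the compounds shown, and "the series" means these compounds.

Compound 1 `COc1ccc(N2CCN(C(=O)Nc3nc4ccc(F)cc4s3)CC2)nn1`: > 10000 nM
Compound 2 `O=C(Nc1nc2ccc(F)cc2s1)N1CCN(c2cccnn2)CC1`: > 10000 nM

Both measured values are limits of the assay and not numbers. In an assay on HEK293 cells for inhibition of transient receptor potential cation channel subfamily V member 1 (Homo sapiens), read by FLIPR, at pH 5.5 (a higher number here means a weaker inhibitor, a lower number a stronger inhibitor), compound 1 gives > 10000 nM, a limit. Compound 2 gives > 10000 nM in this assay, likewise a limit. The step that the two limits leave unreadable from compound 1 to compound 2 therefore has no readable size; what the two measured values show is the limit of > 10000 nM in this assay, at which 2 of the 2 values shown sit.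

Compound 3 `Cc1ccnnc1N1CCN(C(=O)Nc2nc3ccc(F)cc3s2)CC1` is not yet measured in this assay. It differs from compound 2 by methyl in place of hydrogen on an aromatic carbon. Among the measured compounds shown here, the only measured step concerns a different group and is itself unreadable, so it gives no direction for this change; no step beyond the scatter can be read from the data, and compound 2 itself stands only at a limit.

Compound 3 is expected to give 15000 nM in this assay, with a range of 4000 nM to 60000 nM. The step from compound 2 to compound 3 is estimated at a step that the limit leaves unreadable from compound 2 to compound 3, most likely again reported only as a limit.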

Compound 3, half-maximal inhibitory concentration: > 25000 nM
Compound 3 ended at the assay's limit; the forecaster's own chance of this, stated with the estimate: 80%; at least 1.6-fold (0.22 log units) between middle value and limit.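

In this assay, among the compounds shown here, compound 1, compound 2 and compound 3 all stand at limits and not at numbers, so no step among them can be read. The compounds shown leave open how strongly any of them inhibits and whether methyl or methoxy on the pyridazin-3-yl group changes inhibition at all.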